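Notes on the amine nitrogen substituent series

The compounds below may be only part of what the source reports. "The series", "measured", "known", "first", "only" and "open" are said of these compounds alone.

Measured compounds:
compound 1, `CCCS(=O)(=O)N1CC=C(c2ccc3c(c2)CC(C2CCN(Cc4ccccc4)CC2)O3)CC1`, in an ADME assay (liver, Mus musculus) for metabolic stability, using microsomes, with a stated time of 10 min (on this read-out higher numbers stand for a more stable compound and lower numbers for a less stable compound), compound 1 gives "not determined" (no result reported)
compound 2, `CCCS(=O)(=O)N1CC=C(c2ccc3c(c2)CC(C2CCN(S(=O)(=O)CCC)CC2)O3)CC1`, in this assay compound 2 gives "not determined" (no result reported)
compound 3, `CCCS(=O)(=O)N1CC=C(c2ccc3c(c2)CC(C2CCN(c4ncc(Cl)cn4)CC2)O3)CC1`, in this assay compound 3 gives 45%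

Among the measured compounds shown here, compound 1 stands without a single number in this assay; one further entry, compound 2, likewise has no single number, so the only measured value in the set belongs to compound 3.

The step from compound 1 to compound 4, `CCCS(=O)(=O)N1CC=C(c2ccc3c(c2)CC(C2CCN(c4ccc(C(F)(F)F)cn4)CC2)O3)CC1`, is a change on the amine nitrogen in a ring: 5-(trifluoromethyl)pyridin-2-yl in place of benzyl on an amine nitrogen in a ring.

Since compound 1 has no value, the size and direction of the step to compound 4 cannot be set against a measured starting point in this assay, and no expectation of a step beyond the scatter can be stated in either direction. The expectation for compound 4 rests on compound 3 alone, which carries a six-membered aromatic ring with hetero atoms on the same amine nitrogen in a ring and gives 45%.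

Compound 4 is expected to give 45% in this assay, estimated within a range from 20% to 70%.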

Compound 4, percent of the compound remaining: 46%
Compound 4: the middle estimate sits 1 percentage points below what was measured; measured number inside the range.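

In this assay, 5-(trifluoromethyl)pyridin-2-yl in place of 5-chloropyrimidin-2-yl on the amine nitrogen in a ring gives a number 1 percentage points higher from compound 3 to compound 4 (within the scatter), so this position now holds two different aromatic substituents that read alike, where before it held a single measured example. Steps involving compound 1 or compound 2 cannot be read, so the benzyl group of compound 1 cannot be compared with either aromatic substituent. No measurement shown here offers a reason for the close agreement between compound 3 and compound 4.

The compounds shown leave open whether the halogen or trifluoromethyl group on the aromatic ring matters at all, as an unsubstituted pyridin-2-yl would test. They also leave open how an acetyl group or a methyl group on the same nitrogen would read.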